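Cyclopropyl in place of cyano-triazolyl: notes on compound 3

A few compounds are considered here, and "the series" means these few. Any claim that something is new, unique, unknown or untested is made for them only; others in the source may bear on it.

Within the data shown here, compound 1 `CNc1nc(NC2CCCC2)nc(NC2(C#N)CCCCC2)n1` and compound 2 `CNc1nc(NC2(C#N)CCCCC2)nc(-n2cnc(C#N)n2)n1` are the two measured members. In an in vitro assay on Sf21 cells for inhibition of high affinity 3',5'-cyclic-AMP phosphodiesterase 7A (Homo sapiens) (on this read-out higher numbers stand for weaker inhibition and lower numbers for stronger inhibition), compound 1 gives > 5000 nM, which is a limit of the assay rather than a number. In this assay compound 2 gives > 5000 nM, again only a limit. Between them stands a step that the two limits leave unreadable from compound 1 to compound 2, and the evidence amounts to the limit of > 5000 nM in this assay, at which 2 of the 2 values shown sit. Compound 2 therefore has no place on a numerical scale; it stands at a limit only. Compound 3 `CNc1nc(NC2(C#N)CCCCC2)nc(C2CC2)n1` carries the change (cyclopropyl in place of 3-cyano-1H-1,2,4-triazol-1-yl on an aromatic carbon). Among the measured compounds shown here, the only measured step concerns a different replacement and its size is unreadable, so no measured step bears directly on this change. Because compound 2 shows > 5000 nM, compound 3 is expected to stay near that limit, and the step that the limit leaves unreadable from compound 2 to compound 3 is estimated to lie within the scatter. The estimate for compound 3 in this assay is 8000 nM, within 2000 nM to 30000 nM.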

Compound 3, half-maximal inhibitory concentration: 539 nM
Compound 3: middle estimate off by 15-fold (1.17 log units), on the high side; the measured number lies below the stated range.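

Among these compounds, this position, on an aromatic carbon between two ring nitrogen atoms, is the first place where a change can be read: in this assay, cyclopropyl in place of 3-cyano-1H-1,2,4-triazol-1-yl gives an at least 9.2-fold lower number from compound 2 to compound 3 (0.96 log units; beyond the scatter). Cyclopropyl in place of cyclopentylamino at the same place gives an at least 9.2-fold lower number from compound 1 to compound 3 (0.96 log units; beyond the scatter), so two different groups here stay at the limit while cyclopropyl gives a number. Both steps have a limit at one end, so only a minimum size can be read: the limit of > 5000 nM in this assay, at which 2 of the 3 values shown sit.

The step between the two compounds at the limit cannot be read, and cyclopentylamino and 3-cyano-1H-1,2,4-triazol-1-yl cannot be ranked against each other. Going by these compounds, whether the lower number is specific to cyclopropyl, or would also appear with methyl, cyclobutyl or a longer alkyl chain at this place, remains open.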